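Benzylamino for (methylsulfonyl)oxy on the core of compound 1

A few compounds are considered here, and "the series" means these few. Any claim that something is new, unique, unknown or untested is made for them only; others in the source may bear on it.

Compound 1 `CS(=O)(=O)Oc1c(C(=O)NCc2ccc(F)cc2)nc(Br)c2cccnc12` carries a (methylsulfonyl)oxy group on the shared core. In a functional assay on MDA-MB-435 cells (Homo sapiens) for cytotoxicity, read by MTT assay, with a stated time of 72 h (on this read-out lower numbers stand for stronger inhibition and higher numbers for weaker inhibition), compound 1 gives only a limit, > 20000 nM, so its place among the values is open at the weak end (the limit of > 20000 nM in this assay, at which 1 of the 2 values shown sits). Among the measured compounds shown here, compound 2 `N[C@H]1CC[C@H](Nc2c(C(=O)NCc3ccc(F)cc3)nc(N3CCCCC3)c3cccnc23)CC1` differs from compound 1 in more than one place, so no single step connects the two; in this assay compound 2 gives 5000 nM, a number rather than a limit. Compound 3 `O=C(NCc1ccc(F)cc1)c1nc(Br)c2cccnc2c1NCc1ccccc1` remains to be measured in this assay. It differs from compound 1 by benzylamino in place of (methylsulfonyl)oxy on an aromatic carbon. For the measured compounds named here, no pair of measured compounds differing in one place is available, so the size of such a change cannot be read from the data; the only number in hand is that of compound 2 at 5000 nM. The step from compound 1 to compound 3 is expected to run toward stronger inhibition, about an at least 2.5-fold lower number from compound 1 to compound 3 (0.39 log units; beyond the scatter), though a limit result remains possible. Compound 3 is estimated at 8000 nM, with a range from 2500 nM to 25000 nM expected.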

Compound 3, half-maximal inhibitory concentration: > 20000 nM
Compound 3 was reported as a limit; the forecaster's own chance of this, stated with the estimate: 30%; middle value at least 2.5-fold (0.39 log units) from the limit.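

In this assay, compound 1 and compound 3 are both reported only as limits, so no step can be read between them for benzylamino in place of (methylsulfonyl)oxy: the limit of > 20000 nM in this assay, at which 2 of the 3 values shown sit.

The compounds shown leave open how far these two groups differ on the shared core, and which of the several differences from compound 1 goes with the numerical result of compound 2.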